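A few compounds are considered here, and "the series" means these few. Any claim that something is new, unique, unknown or untested is made for them only; others in the source may bear on it.

Compound 1 `CS(=O)(=O)c1coc(C(=O)CCCCCCc2ccccc2)n1`: 389 nM
Compound 2 `COc1coc(C(=O)CCCCCCc2ccccc2)n1`: > 10000 nM

In an assay on HEK-293T cells for inhibition of diacylglycerol lipase-alpha (Homo sapiens), read by colorimetric assay (on this read-out lower numbers stand for stronger inhibition and higher numbers for weaker inhibition), compound 1 gives 389 nM. Compound 2 gives only > 10000 nM, which is a limit of the assay rather than a number. Compound 2 therefore stands at the limit of > 10000 nM in this assay, at which 1 of the 2 values shown sits, reached through an at least 25-fold higher number from compound 1 to compound 2 (1.41 log units; beyond the scatter). Compound 3 `COc1cnc(C(=O)CCCCCCc2ccccc2)o1` differs from compound 2 by a group of 7 heavy atoms (4 carbon, 1 nitrogen, 2 oxygen; one five-membered aromatic ring with 2 hetero atoms) in place of a group of 7 heavy atoms (4 carbon, 1 nitrogen, 2 oxygen; one five-membered aromatic ring with 2 hetero atoms), on a carbonyl carbon. Going by the values given here, no measured step concerns such a rearrangement, so the one measured step does not bear on it directly. Compound 3 is expected to stay weak, with an estimated at least 1.1-fold lower number from compound 2 to compound 3 (0.04 log units; that floor lies within the scatter). The estimate for compound 3 is 9000 nM, between 2000 nM and 30000 nM.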

Compound 3, half-maximal inhibitory concentration: > 10000 nM
Compound 3: no number, only a limit (the forecaster's own chance of this, stated with the estimate: 60%); at least 1.1-fold (0.04 log units) between middle value and limit.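

Going by these compounds alone, compound 2 and compound 3 both give only a limit, not a number, in this assay, and no step between them can be read. The compounds shown leave open whether this rearrangement of the same atoms changes inhibition at all.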